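The compounds below may be only part of what the source reports. "The series", "measured", "known", "first", "only" and "open" are said of these compounds alone.

Compound 1 `CCCCCC(=O)c1ccc(OCCCN2CCN(C(=O)N3CCOCC3)CC2)cc1` is measured in an assay on isolated protein for binding affinity to histamine H2 receptor (Homo sapiens) (on this read-out higher numbers stand for weaker inhibition and lower numbers for stronger inhibition), and gives 17800 nM. Among the two measured compounds it has the lowest number, and its nearest neighbour is compound 2 `CCCCCC(=O)c1ccc(OCCCN2CCN(C(=O)C(C)C)CC2)cc1`, which in this assay gives 29500 nM. Going by the values given here, the only measured step, a 1.7-fold higher number from compound 1 to compound 2 (0.22 log units; within the scatter), swaps the group attached to the carbonyl carbon and stays within the scatter, so the two values cannot be ordered.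

Compound 3 `CCCCCC(=O)c1ccc(OCCCN2CCN(CCCC)CC2)cc1` is not yet measured. It differs from compound 1 in one place: butyl in place of (morpholin-4-yl)carbonyl on an amine nitrogen in a ring. This change goes further than the measured step, since the carbonyl itself is lost rather than only the group on it. Among the compounds with values here, the measured step suggests that what sits on that carbonyl matters little, but no measured pair shows what removing the carbonyl does. A step of a 1.8-fold lower number from compound 1 to compound 3 (0.25 log units; within the scatter) is therefore expected, with wide uncertainty. For compound 3 the expected value in this assay is 10000 nM, within the range 2500 nM to 40000 nM.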

Compound 3, inhibition constant: 7590 nM
Estimate against measurement, compound 3: 1.3-fold (0.12 log units) above, within the range that was stated.
By their numbers in this assay, from the lowest: compound 3; then compounds 1 and 2 (each within the scatter of the next).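

The earlier compounds shown here only exchanged the group on the carbonyl, and their values could not be told apart. Butyl, with no carbonyl at all, on the same amine nitrogen in a ring gives a difference in this assay that the earlier pair did not: a 2.3-fold lower number from compound 1 to compound 3 (0.37 log units; beyond the scatter) and a 3.9-fold lower number from compound 2 to compound 3 (0.59 log units; beyond the scatter), both modest steps towards stronger inhibition. Nothing measured here accounts for this difference.

It remains open whether the gain comes with losing the carbonyl or belongs to the butyl chain itself, as only one group without a carbonyl is shown. A shorter chain such as methyl, a longer one such as hexyl, or a benzyl group on this nitrogen would begin to separate those two readings.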